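A few compounds are considered here, and "the series" means these few. Any claim that something is new, unique, unknown or untested is made for them only; others in the source may bear on it.

In a functional assay on HCT-116 cells (Homo sapiens) for inhibition, read by MTT assay (on this read-out lower numbers stand for stronger inhibition and higher numbers for weaker inhibition), compound 1 (`O=C(COc1ccc(C(=O)/C=C/c2ccccc2)cc1)NO`) gives 620 nM and compound 2 (`COc1ccc(/C=C/C(=O)c2ccc(OCC(=O)NO)cc2)cc1`) gives 620 nM on the same read-out, so compound 2 stands level with compound 1 at the digits shown. Next in the series is compound 3 (`O=C(COc1ccc(C(=O)/C=C/c2ccc(F)cc2)cc1)NO`), which differs from compound 2 by fluoro in place of methoxy on an aromatic carbon (fluoro in place of methoxy on an aromatic carbon, para to a large group). Among the compounds with values here, one measured step bears on this change: methoxy in place of hydrogen on an aromatic carbon gave no change at the digits printed from compound 1 to compound 2 (within the scatter) as its result. Within the data shown here, that is a single pair, and no fluoro compound has been measured yet. On this evidence no step beyond the scatter is expected in this assay and no direction can be favoured. The expected step is a 1.0-fold lower number from compound 2 to compound 3 (0.01 log units; within the scatter) on this reasoning. The estimate for compound 3 is 600 nM with an expected range from 280 nM to 1300 nM on repeated measurement.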

Compound 3, half-maximal inhibitory concentration: 620 nM
The estimate for compound 3 lay 1.0-fold (0.01 log units) below the measured number, within the range that was stated.
By their numbers in this assay, from the lowest: compounds 1, 2 and 3 (each within the scatter of the next).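

In this assay, 4-fluorophenyl in place of 4-methoxyphenyl gives no change at the digits printed from compound 2 to compound 3 (within the scatter) and fluoro in place of hydrogen on the same aromatic carbon gives no change at the digits printed from compound 1 to compound 3 (within the scatter) as its reading. The position now carries a second group besides hydrogen, and across this small set the read-out does not separate hydrogen, methoxy and fluoro, whereas the earlier pair spoke only for methoxy. No supporting measurement bears on why these three compounds read alike.

On these data alone, whether this flat reading holds for an amine, a carboxylic acid or a longer alkoxy chain at this position remains open. The compounds shown also leave open whether any group here can move the number beyond the scatter, and whether the same holds at other carbons of this ring.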